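An oxime in place of the acetyl on the shared core

This account rests on a few compounds, and the source may have more. Where it says the series, first, only, none or still open, it means among the compounds named here.

compound 1 `CCc1c(COc2ccc(Cc3nnn[nH]3)cc2)ccc(C(C)=O)c1O`: 12.6 nM
compound 2 `CCCc1c(COc2ccc(Cc3nnn[nH]3)cc2)ccc(C(C)=O)c1O`: 10 nM

For the measured compounds named here, compound 2 stands at the lowest of the two numbers so far in a functional assay on ileum (Cavia porcellus) for inhibition of cysteinyl leukotriene receptor (Homo sapiens); on this read-out lower numbers stand for stronger inhibition and higher numbers for weaker inhibition; its nearest neighbour is compound 1, and the step of a 1.3-fold lower number from compound 1 to compound 2 (0.10 log units; within the scatter) lies within the scatter, so the two cannot be ranked. Compound 3 `CCCc1c(COc2ccc(Cc3nnn[nH]3)cc2)ccc(/C(C)=N\O)c1O` differs from compound 2 in one place: a group of 4 heavy atoms (2 carbon, 1 nitrogen, 1 oxygen; no ring) in place of a group of 3 heavy atoms (2 carbon, 1 oxygen; no ring), on an aromatic carbon. Going by the values given here, the only measured step concerns the propyl group and leaves the acetyl untouched, so nothing measured bears directly on this change. Among the compounds with values here, with no step to lean on, compound 3 is expected to remain close to compound 2, an estimated step of a 1.6-fold higher number from compound 2 to compound 3 (0.20 log units; within the scatter) in this assay, with a wider band of uncertainty than the scatter alone would give. For compound 3 the estimate in this assay is 16 nM, with a range from 4 nM to 63 nM.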

Compound 3, half-maximal inhibitory concentration: 1580 nM
For compound 3 the middle estimate is 99-fold (1.99 log units) below the measured one; measured number outside the range, above it.
By their numbers in this assay, from the lowest: compounds 2 and 1 (each within the scatter of the next); then compound 3.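

The acetyl position proves far more sensitive than the chain: with the propyl group and the rest of the shared core unchanged, replacing the acetyl with the oxime gives a 160-fold higher number from compound 2 to compound 3 (2.20 log units; beyond the scatter) in this assay. The earlier step, on the chain, stayed within the scatter, so this is the first change among these compounds with a clear effect on the read-out. Nothing available explains the loss.

With a single replacement at this aromatic carbon, the compounds leave open whether the loss is specific to the oxime or follows any departure from the acetyl, as a propanoyl group, a carboxylic acid or an oxime methyl ether might show. They also leave open whether the oxime would cost as much with the shorter chain of compound 1.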